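Bromo for amino on the aryl ring of compound 1

This account rests on a few compounds, and the source may have more. Where it says the series, first, only, none or still open, it means among the compounds named here.

Compound 1, `COC(=O)C1=C(C)N=C(C)/C(=C(\O)OC)C1c1cccc(N)c1`: 2000 nM
Compound 2, `COC(=O)C1=C(C)N=C(C)/C(=C(\O)OC)C1c1c(F)c(F)c(F)c(F)c1F`: 4.37 nM
Compound 3, `COC(=O)C1=C(C)N=C(C)/C(=C(\O)OC)C1c1cc([N+](=O)[O-])ccc1Cl`: 30.2 nM

The three measured compounds share one core and differ only in the aryl ring. In a functional assay (muscle tissue) with Cavia porcellus as the target (a higher number here means that more compound is needed for the effect, a lower number that less compound is needed), compound 1 gives the highest number of the three, 2000 nM; the nearest neighbour is compound 3 with 30.2 nM, a gap well beyond the scatter, and compound 2 lies furthest away with 4.37 nM, a gap that is larger still. Both lower numbers belong to compounds whose aryl ring carries halogen, while the ring of compound 1 carries an amino group and nothing else.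

The next compound, compound 4, `COC(=O)C1=C(C)N=C(C)/C(=C(\O)OC)C1c1cccc(Br)c1`, keeps the core and alters that ring: bromo in place of amino on an aromatic carbon. Read one bond further out, the aryl ring goes from 3-aminophenyl to 3-bromophenyl. For the measured compounds named here, no measured pair shows exactly this step, so the size must be judged from what compounds 2 and 3 show against compound 1: a halogen on the ring goes with a far lower number in this assay. A large downward step, beyond the scatter, is expected for compound 4, namely a 33-fold lower number from compound 1 to compound 4 (1.52 log units; beyond the scatter). For compound 4 the estimate in this assay is 60 nM, with a range from 10 nM to 300 nM.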

Compound 4, half-maximal effective concentration: 1.29 nM
The estimate for compound 4 lay 47-fold (1.67 log units) above the measured number, and the stated range ends above it.
By their numbers in this assay, from the lowest: compound 4; then compound 2; then compound 3; then compound 1.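

For the compounds shown here, compound 4 provides the first comparison here in which a single group on the aryl ring changes while the shared core stays the same, and in this assay that exchange of amino for bromo on an aromatic carbon gives a 1600-fold lower number from compound 1 to compound 4 (3.19 log units; beyond the scatter). Compounds 2 and 3 differ from compound 1 in more than one place on the ring, so they could not tie a change in the number to this one position; this pair shows that the position alone can carry a large step, and that going from 3-aminophenyl to 3-bromophenyl is enough to produce it. No measurement shown here accounts for the size of this step.

Going by these compounds alone, the single pair cannot separate what is lost with the amino group from what is gained with the bromo group, and a hydrogen, methyl, methoxy or hydroxy group in the same place would be needed to place both ends of the step on a wider scale. It also leaves open whether the same exchange would give a step of similar size on an aryl ring that carries other groups as well.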